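Phenyl ether tail: trifluoromethoxy to hydroxy

This account rests on a few compounds, and the source may have more. Where it says the series, first, only, none or still open, it means among the compounds named here.

Measured compounds:
compound 1 `COc1ccc(/C=N/NC(=O)Nc2ccc(Oc3ccnc4cc(OCCCN5CCCCC5)c(OC)cc34)c(F)c2)cc1`: 590 nM
compound 2 `COc1cc2c(Oc3ccc(NC(=O)N/N=C/c4ccc(OC(F)(F)F)cc4)cc3F)ccnc2cc1OCCCN1CCCCC1`: 510 nM

Among the measured compounds shown here, in a functional assay on HT-29 cells (Homo sapiens) for cytotoxicity, read by MTT assay, with a stated time of 72 h (a lower number here means a stronger inhibitor, a higher number a weaker inhibitor), compound 2 holds the lowest of the two numbers, with compound 1 nearest; the single measured step, a 1.2-fold lower number from compound 1 to compound 2 (0.06 log units; within the scatter), lies within the scatter. Compound 3 `COc1cc2c(Oc3ccc(NC(=O)N/N=C/c4ccc(O)cc4)cc3F)ccnc2cc1OCCCN1CCCCC1` differs from compound 2 by hydrogen in place of trifluoromethyl on an oxygen on an aromatic ring. For the measured compounds named here, that earlier step at the same oxygen carried no movement beyond the scatter, and no other measured step bears on this change, so no shift beyond the scatter is expected in this assay. Compound 3 is therefore expected near 600 nM, in the range 250 nM to 1500 nM. The expected step is a 1.2-fold higher number from compound 2 to compound 3 (0.07 log units; within the scatter).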

Compound 3, half-maximal inhibitory concentration: 470 nM
Estimate against measurement, compound 3: 1.3-fold (0.11 log units) above; the measured number falls inside the stated range.
By their numbers in this assay, from the lowest: compounds 3, 2 and 1 (each within the scatter of the next).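

In this assay hydrogen in place of trifluoromethyl gives a 1.1-fold lower number from compound 2 to compound 3 (0.04 log units; within the scatter) and hydrogen in place of methyl gives a 1.3-fold lower number from compound 1 to compound 3 (0.10 log units; within the scatter) on the same oxygen on the aromatic ring. The series at this oxygen now covers hydrogen, methyl and trifluoromethyl, and the free hydroxy reads the same as both ethers, with no step beyond the scatter. No measurement available here offers an explanation for this flat reading.

Going by these compounds, whether an amine or a carboxylic acid in place of the hydroxy, or a longer chain on that oxygen, would move the number remains open. Also open, on these data alone, is whether this flat reading holds outside this assay for these compounds.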